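Amide N-methylation on the dimethylaminopropoxy analogue

This account rests on a few compounds, and the source may have more. Where it says the series, first, only, none or still open, it means among the compounds named here.

For the measured compounds named here, compound 3 `C[C@H](Nc1c(C(N)=O)nnc2ccc(-c3ccc(OCCCN(C)C)nc3)cc12)C1CCOCC1` gives 1.9 nM in an assay on HT-29 cells for inhibition of Serine-protein kinase ATM (Homo sapiens), read by fluorescence, with a stated time of 1 h (on this read-out higher numbers stand for weaker inhibition and lower numbers for stronger inhibition), the lowest of the three numbers so far. Compound 1 `COCc1ccc(-c2ccc3nnc(C(N)=O)c(N[C@@H](C)C4CCOCC4)c3c2)cn1` gives 140 nM in this assay, and the change of its methoxymethyl group to 3-(dimethylamino)propoxy on the aromatic carbon produced a 74-fold lower number from compound 1 to compound 3 (1.87 log units; beyond the scatter). Going by the values given here, compound 2 `CNC(=O)c1nnc2ccc(-c3ccc(COC)nc3)cc2c1N[C@@H](C)C1CCOCC1` gives 330 nM in this assay; the only difference from compound 1 is methyl in place of hydrogen on the amide-type nitrogen, and that step read a 2.4-fold higher number from compound 1 to compound 2 (0.37 log units; beyond the scatter).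

Compound 4 `CNC(=O)c1nnc2ccc(-c3ccc(OCCCN(C)C)nc3)cc2c1N[C@@H](C)C1CCOCC1` is not yet measured in this assay. It differs from compound 3 by methyl in place of hydrogen on an amide-type nitrogen; one bond further out this reads amino to methylamino, carbamoyl to methylcarbamoyl. The same change has been seen once, in the step from compound 1 to compound 2, with a modest rise beyond the scatter. A step of similar size is therefore expected here, a 2.4-fold higher number from compound 3 to compound 4 (0.37 log units; beyond the scatter), with the number rising. For compound 4 in this assay the estimate is 4.5 nM, within a range of 2 nM to 12 nM.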

Compound 4, half-maximal inhibitory concentration: 2.8 nM
The estimate for compound 4 lay 1.6-fold (0.21 log units) above the measured number; measured number inside the range.
By their numbers in this assay, from the lowest: compounds 3 and 4 (each within the scatter of the next); then compound 1; then compound 2.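

In this assay, methyl in place of hydrogen on the amide-type nitrogen of the 3-(dimethylamino)propoxy analogue gives a 1.5-fold higher number from compound 3 to compound 4 (0.17 log units; within the scatter), so this change no longer reads beyond the scatter, although its size agrees with the first reading: the same change on two cores in this assay, a 2.4-fold higher number (0.37 log units; beyond the scatter) from compound 1 to compound 2 and a 1.5-fold higher number (0.17 log units; within the scatter) from compound 3 to compound 4, 1.6-fold (0.20 log units) apart, within the scatter of two such steps

The 3-(dimethylamino)propoxy change now also stands on the methylated amide, with a 120-fold lower number from compound 2 to compound 4 (2.07 log units; beyond the scatter), and its size holds across both amide forms: the same change on two cores in this assay, a 74-fold lower number (1.87 log units; beyond the scatter) from compound 1 to compound 3 and a 120-fold lower number (2.07 log units; beyond the scatter) from compound 2 to compound 4, 1.6-fold (0.20 log units) apart, within the scatter of two such steps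

Across these four compounds, the two changes read as independent, with the group on the aromatic carbon carrying nearly all of the difference.

The amide-type nitrogen is shown only with hydrogen or methyl, so an ethyl group there remains open. Also open, on these data alone, is whether a 2-(dimethylamino)ethoxy chain, a longer chain or a pyrrolidine in place of the dimethylamino group would hold the low numbers of compound 3 and compound 4.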